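Methyl on the aromatic ring nitrogen: outlook for compound 3

The source may report more compounds than this note shows. Statements on the series, on what has been measured and on what is new or still open speak of the compounds shown alone.

Values in a functional assay on LNCaP cells (Homo sapiens) for cytotoxicity, read by MTT assay, with a stated time of 48 h; a higher number here means a weaker inhibitor, a lower number a stronger inhibitor:
compound 1 `Cc1nc(-c2c[nH]c3ccccc23)co1`: 316000 nM
compound 2 `c1ccc2c(-c3coc(C4CCNCC4)n3)c[nH]c2c1`: 476000 nM
compound 3 `Cn1cc(-c2coc(C3CCNCC3)n2)c2ccccc21`: not yet measured

Compound 2 holds the highest of the two numbers in this assay; its nearest neighbour is compound 1, and the step of a 1.5-fold higher number from compound 1 to compound 2 (0.18 log units; within the scatter) is within the scatter, so the two compounds are not distinguished by these data. Compound 3 differs from compound 2 by methyl in place of hydrogen on an aromatic nitrogen. For the measured compounds named here, no measured step concerns this position: the single step available, from compound 1 to compound 2, alters a substituent on an aromatic carbon of the other ring and is itself within the scatter. There is therefore no basis for expecting movement in either direction in this assay; the step is expected to be a 1.1-fold lower number from compound 2 to compound 3 (0.02 log units; within the scatter), not beyond the scatter. Compound 3 is estimated at 450000 nM, with a range from 150000 nM to 1400000 nM.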

Compound 3, half-maximal inhibitory concentration: 400000 nM
Compound 3: middle estimate off by 1.1-fold (0.05 log units), on the high side, within the range that was stated.
By their numbers in this assay, from the lowest: compounds 1, 3 and 2 (each within the scatter of the next).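

In this assay methyl in place of hydrogen on the aromatic nitrogen gives a 1.2-fold lower number from compound 2 to compound 3 (0.08 log units; within the scatter) and so is not distinguished from no change in these data. For the compounds shown here, this is the first reading at this position, and with piperidin-4-yl held constant, the hydrogen on this aromatic nitrogen can be exchanged for methyl without a step beyond the scatter. No measurement is available that would explain the size of this step.

Compound 2 and compound 3 leave open whether a longer chain on this nitrogen, or a chain ending in an amine or a carboxylic acid, would give a step beyond the scatter. They also leave open whether the same methyl exchange gives a similar step when the piperidin-4-yl group is replaced by the methyl of compound 1.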